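Benzofuran swap in a series held at the assay limit

The compounds below may be only part of what the source reports. "The series", "measured", "known", "first", "only" and "open" are said of these compounds alone.

Compound 1 `Nc1nc(N)c2c(-c3cccs3)cn([C@@H]3O[C@H](CO)[C@@H](O)[C@H]3O)c2n1` gives > 20000 nM in a functional assay on HL-60 cells (Homo sapiens) for antiproliferative activity, read by XTT assay, with a stated time of 72 h (a higher number here means a weaker inhibitor, a lower number a stronger inhibitor), as a limit of the assay. Compound 2 `Nc1nc(N)c2c(-c3ccsc3)cn([C@@H]3O[C@H](CO)[C@@H](O)[C@H]3O)c2n1` gives > 20000 nM there, again a limit and not a number. Compound 3 `Nc1nc(N)c2c(-c3cc4ccccc4o3)cn([C@@H]3O[C@H](CO)[C@@H](O)[C@H]3O)c2n1` carries 1-benzofuran-2-yl in place of thiophen-3-yl on an aromatic carbon on the shared core. For the measured compounds named here, the only measured step, a step that the two limits leave unreadable from compound 1 to compound 2 has no readable size. The evidence is the limit of > 20000 nM in this assay, at which 2 of the 2 values shown sit, and no measured size carries over. The expected change in this assay is a number no higher from compound 2 to compound 3 (the limit leaves the size open) with no direction favoured and nothing expected beyond the scatter. Compound 3 is expected at 20000 nM with an estimated range from 7000 nM to 40000 nM and may return only a limit.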

Compound 3, half-maximal inhibitory concentration: > 15000 nM
Compound 3 gave a limit, no number; the forecaster's own chance of this, stated with the estimate: 75%; the middle value lies beyond the limit too.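

Compound 3 gives > 15000 nM in this assay, a limit and not a number. The steps to compound 3 from compound 1 and from compound 2 cannot be read. As far as these compounds go, whether thiophen-2-yl, thiophen-3-yl and 1-benzofuran-2-yl differ in effect on the shared core stays open.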